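The source may report more compounds than this note shows. Statements on the series, on what has been measured and on what is new or still open speak of the compounds shown alone.

Measured so far in a functional assay on LoVo cells (Homo sapiens) for antiproliferative activity, read by MTT assay, with a stated time of 72 h; on this read-out higher numbers stand for weaker inhibition and lower numbers for stronger inhibition:
- compound 1, `COc1cc(/C=C2\CCC/C(=C\c3ccc(F)c(F)c3)C2=O)cc(OC)c1OC`: 2300 nM
- compound 2, `COc1ccccc1/C=C1\CCC/C(=C\c2cc(OC)c(OC)c(OC)c2)C1=O`: 1100 nM

Among the measured compounds shown here, compound 2 holds the lowest of the two numbers in this assay; its only neighbour is compound 1, and the step of a 2.1-fold lower number from compound 1 to compound 2 (0.32 log units; beyond the scatter) separates them. For the measured compounds named here, that step is the sole measured change at the position in question, and it exchanges one substituted aryl for another on the same double-bonded chain carbon bound to a double-bonded ring carbon.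

Compound 3, `COc1cc(/C=C2\CCC/C(=C\c3cccc(O)c3)C2=O)cc(OC)c1OC`, is not yet measured. It differs from compound 2 in one place: 3-hydroxyphenyl in place of 2-methoxyphenyl on a double-bonded chain carbon bound to a double-bonded ring carbon. Going by the values given here, no measured pair shows a hydroxy-substituted aryl at this position, so the only guide is that swapping the aryl there between compound 1 and compound 2 moved the number by a modest amount. On that basis a step of similar size in either direction, or none beyond the scatter, is expected for compound 3; the estimate centres close to compound 2.

Compound 3 is therefore expected to give about 1500 nM in this assay, within a range of 600 nM to 4000 nM, which corresponds to an expected step of a 1.4-fold higher number from compound 2 to compound 3 (0.13 log units; within the scatter).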

Compound 3, half-maximal inhibitory concentration: 4800 nM
Beside the measured number, compound 3's estimate is 3.2-fold (0.51 log units) below it; the measured number lies above the stated range.
By their numbers in this assay, from the lowest: compound 2; then compound 1; then compound 3.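

In this assay, the aryl group on a double-bonded chain carbon bound to a double-bonded ring carbon now has three measured forms, and each exchange among them moves the number beyond the scatter. 3-Hydroxyphenyl sits at the weak end of this short set, with a 4.4-fold higher number from compound 2 to compound 3 (0.64 log units; beyond the scatter) and a 2.1-fold higher number from compound 1 to compound 3 (0.32 log units; beyond the scatter), so the position does not accept any substituted aryl equally and the hydroxy-bearing group ranks behind both 2-methoxyphenyl and 3,4-difluorophenyl. The entering group carries a hydrogen-bond donor where 2-methoxyphenyl has none, but no measurement at hand gives a reason for the loss.

The change from compound 2 to compound 3 replaces the oxygen substituent and also moves it around the aryl ring, so the compounds shown cannot separate the effect of hydroxy against methoxy from the effect of where that oxygen sits. Going by these compounds, it also remains open how this position responds to an aryl bearing an amine or a carboxylic acid, or to a longer chain in place of the aryl.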